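Replacing a benzimidazole on a rapidly cleared compound

This account rests on a few compounds, and the source may have more. Where it says the series, first, only, none or still open, it means among the compounds named here.

Measured in a toxicity assay on microsomes from liver (Homo sapiens) for metabolic stability, read by LC-MS, using NADPH, tested at 1 uM (on this read-out lower numbers stand for slow clearance and higher numbers for fast clearance), so far:
Compound 1 `Cc1nc(-c2nc3ccccc3[nH]2)c(N2CCN(C(=O)Cn3cnc4cccnc43)[C@H](C)C2)s1` gives 23 mL.min-1.g-1
Compound 2 `CCOc1ncc(-c2nc(C(F)(F)F)sc2N2CCN(C(=O)Cn3cnc4ccccc43)[C@H](C)C2)cn1` gives 662 mL.min-1.g-1

Compound 2 holds the higher of the two numbers, beyond the usual scatter from compound 1, although the two differ in several places. Compound 3 `CCOc1ncc(-c2nc(C(F)(F)F)sc2N2CCN(C(=O)Cn3ccc4cnccc43)[C@H](C)C2)cn1` differs from compound 2 in one place, a saturated chain carbon bound to a carbonyl carbon, where a group of 9 heavy atoms (7 carbon, 2 nitrogen; one five-membered aromatic ring with 1 hetero atom, one six-membered aromatic ring with 1 hetero atom) in place of a group of 9 heavy atoms (7 carbon, 2 nitrogen; one five-membered aromatic ring with 2 hetero atoms, one six-membered aromatic ring of carbon only), on a saturated chain carbon bound to a carbonyl carbon describes the swap. Among the compounds with values here, no measured pair isolates this change, so any expectation is uncertain. Compound 2 at 662 mL.min-1.g-1 has room to fall, so a modest decrease, about the size of the scatter, is expected: an estimated 1.9-fold lower number from compound 2 to compound 3 (0.28 log units; within the scatter) is the working guess. Compound 3 is expected at 350 mL.min-1.g-1 within a range of 120 mL.min-1.g-1 to 800 mL.min-1.g-1 as estimated here.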

Compound 3, intrinsic clearance in microsomes: 656 mL.min-1.g-1
Estimate against measurement, compound 3: 1.9-fold (0.27 log units) below; measured number inside the range.
By their numbers in this assay, from the lowest: compound 1; then compounds 3 and 2 (each within the scatter of the next).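

In this assay, exchanging the 1H-benzimidazol-1-yl group for its isomer with one nitrogen in each ring, on a saturated chain carbon bound to a carbonyl carbon, gives a 1.0-fold lower number from compound 2 to compound 3 (0.00 log units; within the scatter). This first one-place comparison shows that rearranging the atoms of this group does not separate the two compounds on clearance. From the compounds shown here alone, it remains open whether a different group at this place, such as an amine or a carboxylic acid, would give a clearly different number. No available measurement offers an explanation for this result.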